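The compounds below may be only part of what the source reports. "The series", "measured", "known", "first", "only" and "open" are said of these compounds alone.

Three compounds have been measured in a functional assay on MCF7 cells (Homo sapiens) for cytotoxicity, read by MTT assay, with a stated time of 72 h; on this read-out higher numbers stand for weaker inhibition of growth and lower numbers for stronger inhibition of growth:

compound 1, `CCCCC[Se]c1nc(NCc2ccccc2)c2ccccc2n1`: 50 nM
compound 2, `[SeH]c1nc(NCc2ccccc2)c2ccccc2n1`: > 100000 nM, which is a limit of the assay and not a number
compound 3, `Nc1nc([SeH])nc2ncccc12`: 37300 nM

Compound 2 sits at the limit of > 100000 nM in this assay, at which 1 of the 3 values shown sits, so only a limit is known for it. From compound 2 to compound 1 the change is pentyl in place of hydrogen on a selenium, and the step is an at least 2000-fold lower number from compound 2 to compound 1 (3.30 log units; beyond the scatter). Compound 3 carries the same hydrogen on selenium as compound 2 but rests on a different core; the difference between the two cores is not broken down here. Compound 4, `CCCCC[Se]c1nc(N)c2cccnc2n1`, has not yet been measured in this assay. It differs from compound 3 by pentyl in place of hydrogen on a selenium, the same change as from compound 2 to compound 1, at the same place, a selenium whose other neighbours are aromatic carbon. Because the step of an at least 2000-fold lower number from compound 2 to compound 1 (3.30 log units; beyond the scatter) was large, a large step is expected from compound 3 to compound 4 as well, a 190-fold lower number from compound 3 to compound 4 (2.27 log units; beyond the scatter), though compound 3 starts from a measured number and a different core, so a somewhat smaller step is expected. Compound 4 is expected to give 200 nM, between 20 nM and 3000 nM.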

Compound 4, concentration for 50% growth inhibition: 22700 nM
Compound 4: middle estimate off by 110-fold (2.05 log units), on the low side, and the stated range ends below it.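

In this assay, pentyl in place of hydrogen on a selenium gives a 1.6-fold lower number from compound 3 to compound 4 (0.22 log units; within the scatter), so the large effect of this change on the core of compound 1 does not carry over to the core of compound 4, and the same change cannot be assumed to act alike on both cores: the same change on two cores in this assay, an at least 2000-fold lower number (3.30 log units; beyond the scatter) from compound 2 to compound 1 and a 1.6-fold lower number (0.22 log units; within the scatter) from compound 3 to compound 4, at least 1200-fold (3.08 log units) apart, beyond the scatter of two such steps The earlier step starts from compound 2, whose value is a limit of the assay and not a number: the limit of > 100000 nM in this assay, at which 1 of the 4 values shown sits. These compounds show that the result of adding pentyl depends on the core in this small set, but they do not show which feature of the core decides it, since the two cores differ in more than one place.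

The compounds shown leave open how a shorter chain such as methyl or a longer chain such as octyl on the selenium would behave on either core. They also leave open whether a carboxylic acid on the pentyl chain would alter either result.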